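This account rests on a few compounds, and the source may have more. Where it says the series, first, only, none or still open, it means among the compounds named here.

Measured in a physicochemical assay for solubility, using the shake flask method, in phosphate buffer, with a stated time of 24 h, at pH 7.4; a lower number here means a less soluble compound, a higher number a more soluble compound:
- compound 1 `CC(Sc1nc2c(cnn2C)c(=O)n1-c1ccccc1)c1ccccn1`: 20000 nM
- compound 2 `CC(Sc1nc2c(cnn2C)c(=O)n1-c1ccccc1)c1cccc(O)c1`: 21000 nM
- compound 3 `Cn1ncc2c(=O)n(-c3ccccc3)c(SCc3cccc(F)c3)nc21`: < 700 nM (a limit, not a number)

Only a limit is known for compound 3, namely < 700 nM. The next compound, compound 4 `CC(Sc1nc2c(cnn2C)c(=O)n1-c1ccccc1)c1ccccc1`, is reached by 1-phenylethyl in place of 3-fluorobenzyl on a sulfur. This places 1-phenylethyl in place of 3-fluorobenzyl on a sulfur whose other neighbour is an aromatic carbon.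

Among the compounds with values here, three measured steps bear on this change. Swapping pyridin-2-yl for 3-hydroxyphenyl on the ethyl chain gave a 1.1-fold higher number from compound 1 to compound 2 (0.02 log units; within the scatter). The two steps to the 3-fluorobenzyl group were both large, at an at least 28-fold lower number from compound 1 to compound 3 (1.45 log units; beyond the scatter) and an at least 30-fold lower number from compound 2 to compound 3 (1.47 log units; beyond the scatter). Within the data shown here, each of these large steps changes the chain and the ring together, so no measured step isolates the chain alone.

Compound 4 keeps the ethyl chain of compound 1 and compound 2, but its ring is plain phenyl and carries neither of their groups. It therefore seems closer to compound 3, whose value is < 700 nM, than to compound 2, whose value is 21000 nM. Only a small upward step is expected, estimated as an at least 1.4-fold higher number from compound 3 to compound 4 (0.15 log units; that floor lies within the scatter), and the assay may again report only a limit. The estimate for compound 4 is 1000 nM, with an expected range from 400 nM to 5000 nM.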

Compound 4, solubility: 8000 nM
For compound 4 the middle estimate is 8.0-fold (0.90 log units) below the measured one, outside the stated range (above it).
By their numbers in this assay, from the lowest: compound 4; then compounds 1 and 2 (each within the scatter of the next). At a limit, below all of these: compound 3.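

In this assay, 1-phenylethyl in place of 3-fluorobenzyl on the sulfur gives an at least 11-fold higher number from compound 3 to compound 4 (1.05 log units; beyond the scatter); this step is only a floor, as compound 3 carries a limit and not a number: the limit of < 700 nM in this assay, at which 1 of the 4 values shown sits.

Within the data shown here, with the ethyl chain held constant, the new compound also gives the first single-group steps on the aromatic ring, with hydrogen in place of hydroxy giving a 2.6-fold lower number from compound 2 to compound 4 (0.42 log units; beyond the scatter) and phenyl in place of pyridin-2-yl giving a 2.5-fold lower number from compound 1 to compound 4 (0.40 log units; beyond the scatter). Both of these steps are modest, so neither the hydroxy nor the pyridine nitrogen is needed to keep compound 4 clear of the limit reported for compound 3, and the large drop seen earlier is not matched by simply removing those groups.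

The step to compound 4 still changes the chain and the fluorine together, so their separate shares remain unresolved. Going by these compounds, a plain benzyl group or a 1-(3-fluorophenyl)ethyl group on the sulfur would separate them, and how an amine or a carboxylic acid on the ring would read in this assay also remains open.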